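This account rests on a few compounds, and the source may have more. Where it says the series, first, only, none or still open, it means among the compounds named here.

In a functional assay on DU-145 cells (Homo sapiens) for cytotoxicity, read by trypan blue exclusion, with a stated time of 96 h (a lower number here means a stronger inhibitor, a higher number a weaker inhibitor), compound 1 (`COC(=O)CNc1cc(NS(=O)(=O)/C=C/c2c(OC)cc(OC)cc2OC)ccc1OC`) gives 350 nM and compound 2 (`COC(=O)C(C)(C)Nc1cc(NS(=O)(=O)/C=C/c2c(OC)cc(OC)cc2OC)ccc1OC`) gives 200 nM. Compound 3 (`COC(=O)C(Nc1cc(NS(=O)(=O)/C=C/c2c(OC)cc(OC)cc2OC)ccc1OC)c1ccccc1`) is the weakest of the three at 2500 nM and sits beyond the scatter of both.

Compound 4 (`COc1cc(OC)c(/C=C/S(=O)(=O)Nc2ccc(OC)c(NC(C)C(=O)O)c2)c(OC)c1`) differs from compound 3 by 1-carboxyethyl in place of methoxycarbonyl)(benzyl on a nitrogen on an aromatic ring, with 1-carboxyethyl in place of methoxycarbonyl)(benzyl on a nitrogen on an aromatic ring.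

The phenyl-bearing side chain accounts for the two large measured steps, a 7.1-fold higher number from compound 1 to compound 3 (0.85 log units; beyond the scatter) and a 13-fold higher number from compound 2 to compound 3 (1.10 log units; beyond the scatter), while a 1.8-fold lower number from compound 1 to compound 2 (0.24 log units; within the scatter) stays within the scatter. Among the measured compounds shown here, no measured step covers the free acid.

A clear fall is therefore expected, estimated as a 10-fold lower number from compound 3 to compound 4 (1.00 log units; beyond the scatter) in this assay.

The estimated value for compound 4 is 250 nM, with an expected range of 60 nM to 900 nM.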

Compound 4, half-maximal inhibitory concentration: 40 nM
For compound 4 the middle estimate is 6.3-fold (0.80 log units) above the measured one; measured number below the stated range.
By their numbers in this assay, from the lowest: compound 4; then compounds 2 and 1 (each within the scatter of the next); then compound 3.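

Among the compounds shown here, on the nitrogen on an aromatic ring, 1-carboxyethyl gives the lowest number in this assay of the series so far, with steps from all three methoxycarbonyl-bearing compounds (a 63-fold lower number from compound 3 to compound 4 (1.80 log units; beyond the scatter); a 5.0-fold lower number from compound 2 to compound 4 (0.70 log units; beyond the scatter); an 8.8-fold lower number from compound 1 to compound 4 (0.94 log units; beyond the scatter)). The position therefore accepts a free carboxylic acid, not only an ester, with a gain in each comparison. Nothing available explains this gain.

The side chains also differ beyond the acid, so its share of the gain stays unseparated. A 1-(methoxycarbonyl)ethyl group, a primary amide or a longer chain ending in a carboxylic acid would test this.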